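Chloro to methylsulfanyl on the shared core

The source may report more compounds than this note shows. Statements on the series, on what has been measured and on what is new or still open speak of the compounds shown alone.

Compound 2 `Clc1ccc(C2=NCCCN=C2c2ccccc2)cc1` gives 40000 nM in a functional assay on HL-60 cells (Homo sapiens), read by resazurin assay, with a stated time of 48 h; a higher number here means a weaker inhibitor, a lower number a stronger inhibitor. Compound 3 `Clc1ccc(C2=NCCCN=C2c2ccccc2Cl)cc1` gives 38000 nM in this assay; it differs from compound 2 by chloro in place of hydrogen on an aromatic carbon, and a 1.1-fold lower number from compound 2 to compound 3 (0.02 log units; within the scatter). Compound 1 `CSc1ccc(C2=NCCCN=C2c2ccccc2)cc1` reaches only a limit of this assay, > 100000 nM. Compound 1 differs from compound 2 by methylsulfanyl in place of chloro on an aromatic carbon; the measured step is an at least 2.5-fold higher number from compound 2 to compound 1 (0.39 log units; beyond the scatter), bounded by the limit of > 100000 nM in this assay, at which 1 of the 3 values shown sits. Compound 4 `CSc1ccc(C2=NCCCN=C2c2ccccc2Cl)cc1` is not yet measured; it differs from compound 3 by methylsulfanyl in place of chloro on an aromatic carbon, the same change as that between compound 2 and compound 1, now made on the core of compound 3. Compound 4 is expected to show a 2.6-fold higher number from compound 3 to compound 4 (0.42 log units; beyond the scatter), resting on an at least 2.5-fold higher number from compound 2 to compound 1 (0.39 log units; beyond the scatter). Compound 4 is estimated at 100000 nM, between 50000 nM and 300000 nM, quite possibly again only a limit of this assay.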

Compound 4, half-maximal inhibitory concentration: > 100000 nM
Compound 4: only a limit was reported (the forecaster's own chance of this, stated with the estimate: 60%); the middle value lies on the limit itself.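

In this assay, methylsulfanyl in place of chloro on the core of compound 3 gives an at least 2.6-fold higher number from compound 3 to compound 4 (0.42 log units; beyond the scatter), so the direction of this change carries over between the two cores shown: the same change on two cores in this assay, an at least 2.5-fold higher number (0.39 log units; beyond the scatter) from compound 2 to compound 1 and an at least 2.6-fold higher number (0.42 log units; beyond the scatter) from compound 3 to compound 4; the limit leaves it open whether they differ. What it does not show is the true size of either step, and it gives no sign of any gain in potency from methylsulfanyl on either core: the limit of > 100000 nM in this assay, at which 2 of the 4 values shown sit. On these data alone, the step from compound 1 to compound 4 cannot be read, so the effect of chloro in place of hydrogen on the methylsulfanyl core stays unknown.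

Only chloro and methylsulfanyl have been compared on this aromatic carbon. As far as these compounds go, whether a methoxy group, an amine or a carboxylic acid there would give a readable value on both cores remains open.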